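The compounds below may be only part of what the source reports. "The series", "measured", "known", "first", "only" and "open" are said of these compounds alone.

Working notes on the series.

Of the compounds shown here, two have numbers so far. Compound 1 `Cc1ccc(NC(=O)Nc2cccc(NC(=O)c3ccccn3)c2)cc1` and compound 2 `O=C(Nc1cccc(NC(=S)Nc2ccccc2)c1)c1ccccn1` share the same core, with a urea in compound 1 and a thiourea in compound 2, together with a second difference on the terminal ring. In a functional assay on A549 cells (Homo sapiens) for antiproliferative activity, read by MTT assay, with a stated time of 48 h (on this read-out lower numbers stand for stronger inhibition and higher numbers for weaker inhibition), compound 1 gives 20 nM, while in this assay compound 2 gives 4400 nM. Compound 2 stands at the highest of the two numbers; the nearest is compound 1, a much lower number, and the gap between the two lies beyond the scatter. Within the data shown here, no single-point step between measured compounds is available, so these two values show only that the two structures sit far apart on this read-out.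

Compound 3 `O=C(Nc1cccc(NC(=S)Nc2ccc([N+](=O)[O-])cc2)c1)c1ccccn1` is the next entry for this assay. It differs from compound 2 in one place: nitro in place of hydrogen on an aromatic carbon. Among the measured compounds shown here, no measured pair shows what this change does. For the measured compounds named here, with no comparable step in hand, the expectation for the move from compound 2 to compound 3 is a step of a 1.3-fold lower number from compound 2 to compound 3 (0.10 log units; within the scatter), most likely none beyond the scatter, with a wide range in either direction. On that basis compound 3 is estimated at 3500 nM in this assay, expected between 900 nM and 14000 nM.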

Compound 3, half-maximal inhibitory concentration: 450 nM
Compound 3: middle estimate off by 7.8-fold (0.89 log units), on the high side, and the stated range ends above it.
By their numbers in this assay, from the lowest: compound 1; then compound 3; then compound 2.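

In this assay, among these compounds, nitro in place of hydrogen, phenyl to 4-nitrophenyl, gives a 9.8-fold lower number from compound 2 to compound 3 (0.99 log units; beyond the scatter), the first change that can be read in one place. This shows that the position para to a large group on the six-membered aromatic ring of carbon only is not silent: a substituent there moves the number beyond the scatter, towards stronger inhibition. The step holds for the thiourea compounds alone and for this one group, so it establishes that the position responds, not which feature of nitro matters. No measurement at hand bears on the reason for this step.

Still open, going by these compounds, is whether an amine, a methoxy group or a chlorine at the same position would move the number in the same direction, or whether nitro at another place on that ring would do so. Also open is what the thiourea itself contributes, since no compound shown differs from compound 1 at the urea alone, and whether nitro would have a comparable effect on the urea side.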